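Cyanoguanidine chain extension at the amine nitrogen

This account rests on a few compounds, and the source may have more. Where it says the series, first, only, none or still open, it means among the compounds named here.

Compound 1 `O=c1ccc(-c2ccccc2)nn1CCCCNC(=S)Nc1ccc(Cl)cc1`: > 100 mg/kg
Compound 2 `N#CNC(=N)NCCCCCn1nc(-c2ccccc2)ccc1=O`: > 100 mg/kg
Compound 3 `CC/N=C(/NC#N)NCCCCn1nc(-c2ccccc2)ccc1=O`: 92 mg/kg

In a functional assay on the whole organism (stomach) with Rattus norvegicus as the target (on this read-out higher numbers stand for an effect only at larger amounts of compound and lower numbers for an effect already at smaller amounts), compound 1 reaches only > 100 mg/kg, a limit of the assay. Compound 2 likewise gives > 100 mg/kg, which is a limit. Compound 3 gives 92 mg/kg in this assay. Compound 2 thus stands at the limit of > 100 mg/kg in this assay, at which 2 of the 3 values shown sit, and the step of an at least 1.0-fold lower number from compound 2 to compound 3 (0.03 log units; that floor lies within the scatter) lies within the scatter, so nothing shown separates it from compound 3. Compound 4 `CCC/N=C(/NC#N)NCCCCCn1nc(-c2ccccc2)ccc1=O` differs from compound 2 by a group of 8 heavy atoms (5 carbon, 3 nitrogen; no ring) in place of a group of 5 heavy atoms (2 carbon, 3 nitrogen; no ring), on an amine nitrogen. Within the data shown here, the only measured step that bears on this region, an at least 1.0-fold lower number from compound 2 to compound 3 (0.03 log units; that floor lies within the scatter), was flat, so no movement beyond the scatter is expected in this assay. Compound 4 is therefore expected to give 120 mg/kg (50 mg/kg to 400 mg/kg). The step that the limit leaves unreadable from compound 2 to compound 4 is expected to stay within the scatter.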

Compound 4, dose for half-maximal effect: > 100 mg/kg
Compound 4 gave a limit, no number; the forecaster's own chance of this, stated with the estimate: 70%; the middle value does not contradict the limit.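

Compound 2 and compound 4 both give only a limit in this assay, so the step between them cannot be read. The compounds shown leave open whether the group of 8 heavy atoms on the amine nitrogen changes the effect at all.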